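This account rests on a few compounds, and the source may have more. Where it says the series, first, only, none or still open, it means among the compounds named here.

Compound 1 `Cn1nc2c(=O)n(CC3(O)CCN(Cc4ccc(-c5ccco5)cc4Cl)CC3)cnc2c1-c1ccc(C2(N)CC2)cc1`: 0.617 h
Compound 2 `Cn1nc2c(=O)n(CC3(O)CCN(Cc4ccc(-c5cnco5)cc4Cl)CC3)cnc2c1-c1ccc(CN)cc1`: 3.85 h

In an ADME assay on microsomes from liver (Rattus norvegicus) for metabolic stability (a lower number here means that the compound disappears faster, a higher number that the compound lasts longer), compound 1 gives 0.617 h, the lower of the two numbers. Compound 2 gives 3.85 h, and the gap between them lies beyond the usual scatter. These two compounds differ in more than one place, so their gap cannot be tied to any single group.

The next compound, compound 3 `Cn1nc2c(=O)n(CC3(O)CCN(Cc4ccc(-c5ccco5)cc4Cl)CC3)cnc2c1-c1ccc(CNC=O)cc1`, has not yet been measured. It carries (formylamino)methyl in place of 1-aminocyclopropyl on an aromatic carbon, para to a large group ((formylamino)methyl in place of 1-aminocyclopropyl on an aromatic carbon). Among the measured compounds shown here, no measured pair shows what this exchange does on its own, so any forecast is uncertain. Compound 1, at 0.617 h, has the lower number, and compound 2, at 3.85 h, shows that a longer half-life is possible with this shared core. A modest rise in this assay is therefore expected, one that may not clear the scatter. The expected change is a 1.8-fold higher number from compound 1 to compound 3 (0.25 log units; within the scatter). For compound 3, the estimated half-life is 1.1 h, with an expected range from 0.45 h to 3 h.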

Compound 3, half-life: 0.55 h
Compound 3: the middle estimate sits 2.0-fold (0.30 log units) above what was measured; the range from low to high includes it.
By their numbers in this assay, from the lowest: compounds 3 and 1 (each within the scatter of the next); then compound 2.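

In this assay, putting (formylamino)methyl in place of 1-aminocyclopropyl on this aromatic carbon, para to a large group, gives a 1.1-fold lower number from compound 1 to compound 3 (0.05 log units; within the scatter), so the two compounds cannot be told apart. Among the compounds shown here, this is the first direct reading at this position: the three-membered carbon ring leaves and an open chain with a double bond enters, while the counts of heavy atoms, hydrogen-bond donors and hydrogen-bond acceptors stay the same, and this particular exchange leaves the half-life within the usual scatter. Nothing at hand explains why the two groups give matching numbers.

Compound 2 differs from both of these compounds in more than one place, so its number still cannot be tied to the group at this position or to any other single group. From the compounds shown here alone, whether the position stays this flat for other groups, such as a hydroxymethyl, a carboxylic acid or a longer chain ending in an amine, remains open, since one step between two groups says little about the others.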